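Replacing an Aryl Ether With a Benzyl Group

The source may hold more compounds than are shown below. What is called first, only, known or untested is meant among the compounds shown, and "the series" means these compounds.

Measured compounds:
compound 1 `N#Cc1ccc(C2OCC(C/C=C\CCC(=O)O)C(c3cccnc3)O2)cc1` gives 1290 nM
compound 2 `O=C(O)CC/C=C\CC1COC(c2ccsc2)OC1c1cccnc1` gives 1580 nM
compound 3 `CC(C)(C)c1ccc(OC(C)(C)C2OCC(C/C=C\CCC(=O)O)C(c3cccnc3)O2)cc1` gives 1910 nM

All three compounds share one core and were tested in a functional assay for inhibition, with Homo sapiens as the target; a higher number here means weaker binding, a lower number tighter binding. The three numbers fall close together: the gaps from compound 3 to compound 2 and to compound 1 both lie within the usual scatter of repeated measurements, so compound 3 cannot be set apart from the other two on these values.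

Compound 4 `CC(C)(Cc1ccccc1)C1OCC(C/C=C\CCC(=O)O)C(c2cccnc2)O1` has not yet been measured. It differs from compound 3 in a single place: benzyl in place of 4-(tert-butyl)phenoxy on a saturated chain carbon bound to two saturated chain carbons and a saturated ring carbon

Among the compounds with values here, only one measured step exists, a 1.2-fold higher number from compound 1 to compound 2 (0.09 log units; within the scatter), and it changes a group on a saturated ring carbon, not on the saturated chain carbon altered here. It shows that exchanging one aromatic group for another at that other place left the number within the scatter, but it does not speak directly to the present change. Within the data shown here, no measured step touches the saturated chain carbon at all.

With nothing pointing either way, the step from compound 3 to compound 4 is expected to stay within the scatter, a 1.1-fold lower number from compound 3 to compound 4 (0.05 log units; within the scatter). Compound 4 is therefore estimated at 1700 nM, within a range from 600 nM to 5000 nM.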

Compound 4, dissociation constant: 513 nM
Compound 4: the middle estimate sits 3.3-fold (0.52 log units) above what was measured, and the stated range ends above it.
By their numbers in this assay, from the lowest: compound 4; then compounds 1, 2 and 3 (each within the scatter of the next).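

In this assay, within the data shown here, benzyl in place of 4-(tert-butyl)phenoxy on this saturated chain carbon gives a 3.7-fold lower number from compound 3 to compound 4 (0.57 log units; beyond the scatter), so a change here can move the number beyond the scatter, something the earlier compounds, all within the scatter of one another, never showed. Compound 4 also separates from the two compounds that carry a single aromatic group on the saturated ring carbon, with a 3.1-fold lower number from compound 2 to compound 4 (0.49 log units; beyond the scatter) against thiophen-3-yl and a 2.5-fold lower number from compound 1 to compound 4 (0.40 log units; beyond the scatter) against 4-cyanophenyl, which gives it the lowest number of the four in this assay. Nothing in the data shown accounts for this gain.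

The compounds shown leave open whether the lower number goes with losing the ether oxygen or with losing the tert-butyl group, as the change removes both at once. Plain phenoxy and 4-(tert-butyl)benzyl at this carbon would pull those two apart, and phenethyl, with its longer chain, would show whether the aromatic ring can sit further out.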